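Ether substituent and receptor displacement in a small series

A few compounds are considered here, and "the series" means these few. Any claim that something is new, unique, unknown or untested is made for them only; others in the source may bear on it.

Measured so far in an assay on CHO cells for displacement of a labelled ligand from adenosine receptor A3 (Homo sapiens), read by scintillation counting, with a stated time of 120 min, tested at 1 uM; a higher number here means more inhibition at the concentration tested (going by the name of the read-out), a lower number less inhibition:
Compound 1, `CCOc1ccc(-c2c(C#N)c(N)nc(SCc3ccn[nH]3)c2C#N)cc1`, gives 18%.
Compound 2, `N#Cc1c(N)nc(SCC(N)=O)c(C#N)c1-c1ccc(OCC2CC2)cc1`, gives 8%.
Compound 3, `N#Cc1c(N)nc(SCc2ccn[nH]2)c(C#N)c1-c1ccc(OCC2CC2)cc1`, gives 6%.

Compound 2 stands second highest of the three numbers. Its nearest neighbour is compound 3, whose value lies within the scatter of compound 2; the furthest is compound 1, and that gap too lies within the scatter. Between compound 2 and compound 3 the change on the saturated chain carbon bound to a sulfur gives a number 2 percentage points lower from compound 2 to compound 3 (within the scatter), so the thioether side chain does not separate these two compounds.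

Compound 4, `CCOc1ccc(-c2c(C#N)c(N)nc(SCC(N)=O)c2C#N)cc1`, has not yet been measured. It differs from compound 2 by methyl in place of cyclopropyl on a saturated chain carbon bound to an oxygen on an aromatic ring. Among the measured compounds shown here, the only measured step touching this position runs the other way, from compound 1 to compound 3, where cyclopropyl replaces methyl and the inhibition drops: a number 12 percentage points lower from compound 1 to compound 3 (beyond the scatter). Reversing that change on compound 2 is therefore expected to raise the number by a modest amount, beyond the scatter.

The step from compound 2 to compound 4 is estimated as a number 12 percentage points higher from compound 2 to compound 4 (beyond the scatter), because a number 12 percentage points lower from compound 1 to compound 3 (beyond the scatter) went the opposite way. Compound 4 is thus expected to show 20% in this assay, within a range from 6% to 34%.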

Compound 4, a percentage reported as inhibition, at one concentration (the size of the read-out at that concentration, not a potency): 20%
Estimate against measurement, compound 4: no gap at the digits printed; low and high end bracket the measured number.
By their numbers in this assay, from the lowest: compounds 3, 2, 1 and 4 (each within the scatter of the next, the first and the last beyond it).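

In this assay the change from cyclopropylmethoxy to ethoxy now reads on a second side chain at the sulfur, the carbamoyl one: a number 12 percentage points higher from compound 2 to compound 4 (beyond the scatter). Among the compounds shown here, the step therefore no longer rests on the single pair of pyrazole compounds, and its size holds from one core to the other: the same change on two cores in this assay, a number 12 percentage points lower (beyond the scatter) from compound 1 to compound 3 and a number 12 percentage points lower (beyond the scatter) from compound 4 to compound 2, 0 percentage points apart, within the scatter of two such steps. The side chain on the sulfur also fails to separate the two ethoxy compounds, a number 2 percentage points higher from compound 1 to compound 4 (within the scatter), so carbamoyl and 1H-pyrazol-5-yl remain interchangeable in this read-out with either ether, and the two changes show no dependence on each other across these four compounds: the same change on two cores in this assay, a number 2 percentage points lower (within the scatter) from compound 2 to compound 3 and a number 2 percentage points lower (within the scatter) from compound 4 to compound 1, 0 percentage points apart, within the scatter of two such steps.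

As far as these compounds go, with only methyl and cyclopropyl compared on the saturated chain carbon bound to the oxygen, it stays open whether the step follows the three-membered ring itself or the larger group, and an open propyl chain or an amine-bearing chain there would test this. All four numbers also come from a single concentration and stay low, so they give no potency and do not show how far the ether change could carry the inhibition.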